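The source may report more compounds than this note shows. Statements on the series, on what has been measured and on what is new or still open speak of the compounds shown alone.

Compound 1 `CCC(CC)(c1ccc(OCC(=O)C(C)(C)Cc2ccccc2)c(C)c1)c1ccc(OC[C@@H](O)CO)c(C)c1`: 21000 nM
Compound 2 `CCC(CC)(c1ccc(OCC(=O)C(C)(C)CCc2ccccc2)c(C)c1)c1ccc(OC[C@@H](O)CO)c(C)c1`: 23000 nM
Compound 3 `CCC(CC)(c1ccc(OCC(=O)C(C)(C)CCCCc2ccccc2)c(C)c1)c1ccc(OC[C@@H](O)CO)c(C)c1`: only a limit, > 30000 nM

In an assay on HL-60 cells for activation of vitamin D3 receptor (Homo sapiens) (a lower number here means that less compound is needed, a higher number that more compound is needed for the effect), compound 1 holds the lowest of the two numbers; the nearest is a 1.1-fold higher number from compound 1 to compound 2 (0.04 log units; within the scatter). The third value is a limit, (the limit of > 30000 nM in this assay, at which 1 of the 3 values shown sits). Compound 4 `CCC(CC)(c1ccc(OCC(=O)C(C)(C)Cc2ccc3ccccc3c2)c(C)c1)c1ccc(OC[C@@H](O)CO)c(C)c1` differs from compound 1 by naphthalen-2-yl in place of phenyl on a saturated chain carbon, two bonds along the chain from a carbonyl carbon. Going by the values given here, the steps that bear on this are a 1.1-fold higher number from compound 1 to compound 2 (0.04 log units; within the scatter) and an at least 1.4-fold higher number from compound 1 to compound 3 (0.15 log units; that floor lies within the scatter), both lengthening the chain at this carbon rather than enlarging the ring; neither moved beyond the scatter. A larger aromatic group at the same place is therefore expected to give at most a small rise, if any, in this assay: a 1.2-fold higher number from compound 1 to compound 4 (0.08 log units; within the scatter). For compound 4 the estimate is 25000 nM, between 12000 nM and 50000 nM.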

Compound 4, half-maximal effective concentration: > 30000 nM
Compound 4 gave a limit, no number; the forecaster's own chance of this, stated with the estimate: 30%; at least 1.2-fold (0.07 log units) between middle value and limit.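

In this assay compound 4 returns a limit, not a number, so two aromatic rings at this carbon, like the longer 3-phenylpropyl chain of compound 3, give no readable value: the limit of > 30000 nM in this assay, at which 2 of the 4 values shown sit.

The floors, an at least 1.4-fold higher number from compound 1 to compound 4 (0.15 log units; that floor lies within the scatter) and an at least 1.3-fold higher number from compound 2 to compound 4 (0.11 log units; that floor lies within the scatter), show no step beyond the scatter, and the step between the two limits cannot be read. Going by these compounds, the size of the change from phenyl to naphthalen-2-yl therefore stays unknown, with only its direction hinted.

On these data alone, whether an amine or a carboxylic acid in place of phenyl at this carbon would move the value beyond the scatter from compound 1 remains open.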